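The compounds below may be only part of what the source reports. "The series", "measured", "known", "first", "only" and "open" are said of these compounds alone.

Compound 1 `CCOC(=O)c1cnn2c1N(C(=O)Nc1ccccc1F)C(c1ccccc1)C2` gives 7.5 nM
Compound 2 `CCOC(=O)c1cnn2c1N(C(=O)Nc1cccc(F)c1)C(c1ccccc1)C2` gives 111 nM
Compound 3 `CCOC(=O)c1cnn2c1N(C(=O)Nc1cccc3ccccc13)C(c1ccccc1)C2` gives 206 nM

All three values come from a functional assay on cells (Neutrophil, Homo sapiens) for inhibition, with a stated time of 10 min (on this read-out lower numbers stand for stronger inhibition and higher numbers for weaker inhibition), and the three compounds differ only in the group on an amide-type nitrogen. Compound 2 is the starting point here. Its gap on one side is large (a 15-fold higher number from compound 1 to compound 2 (1.17 log units; beyond the scatter)) and its gap on the other side lies within the scatter (a 1.9-fold higher number from compound 2 to compound 3 (0.27 log units; within the scatter)).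

The next compound is compound 4 `NC(=O)c1cnn2c1N(C(=O)Nc1cccc(F)c1)C(c1ccccc1)C2` and the change from compound 2 is this one (amino in place of ethoxy on a carbonyl carbon): amino in place of ethoxy on a carbonyl carbon, so that ethoxycarbonyl becomes carbamoyl.

Among the measured compounds shown here, no measured step touches this carbonyl carbon. All three steps concern the amide-type nitrogen, so they bear on the new change only indirectly. They show that a single swap in these compounds can be large (a 27-fold higher number from compound 1 to compound 3 (1.44 log units; beyond the scatter)) or can stay within the scatter. They do not fix a direction for the new change. As a judgement with a wide margin, a moderately higher number is expected in this assay and a large step remains possible. The estimate means an expected step (a 3.2-fold higher number from compound 2 to compound 4 (0.50 log units; beyond the scatter)) of that moderate kind. Compound 4 is estimated at 350 nM with 60 nM to 2500 nM as the expected range.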

Compound 4, half-maximal inhibitory concentration: 1.2 nM
Beside the measured number, compound 4's estimate is 290-fold (2.46 log units) above it, and the stated range ends above it.
By their numbers in this assay, from the lowest: compound 4; then compound 1; then compounds 2 and 3 (each within the scatter of the next).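

In this assay the swap of ethoxy for amino on a carbonyl carbon gives a 93-fold lower number from compound 2 to compound 4 (1.97 log units; beyond the scatter) and so much stronger inhibition. Among the compounds shown here, the earlier steps all concerned the group on the amide-type nitrogen, so this is the first sign that the carbonyl carbon is also a sensitive position, where one small swap can produce a large step and where carbamoyl is far better tolerated than ethoxycarbonyl in this compound pair. Nothing available explains the gain, and the swap changes several things at once, removing a larger group with a hydrogen-bond acceptor and bringing in a smaller one with a hydrogen-bond donor.

The compounds shown do not separate these changes: a methylamino or dimethylamino group on the same carbonyl carbon, or a carboxylic acid in place of the ethoxycarbonyl, would help to show which feature of the amino group matters. They also leave open whether carbamoyl brings a similar step when the 3-fluorophenyl group on the amide-type nitrogen is replaced by 2-fluorophenyl or naphthalen-1-yl.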